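This account rests on a few compounds, and the source may have more. Where it says the series, first, only, none or still open, it means among the compounds named here.

Compound 1 `CO[C@@H]1C/C=C(\C)C(=O)N(C)[C@@H](C(C)C)C(=O)N[C@H](Cc2cc(Cl)c(O)c(Cl)c2)C(=O)N[C@@H](C(C)C)C(=O)O[C@H](c2ccccc2)[C@H](C)/C=C/C=C/1C`: 21.6 nM. Compound 2 `CC[C@H](C)[C@H]1C(=O)N[C@H](Cc2cc(Cl)c(O)c(Cl)c2)C(=O)N[C@@H](C(C)(C)O)C(=O)O[C@H](c2ccccc2)[C@H](C)/C=C/C=C(\C)[C@H](OC)C[C@@H]2O[C@@]2(C)C(=O)N1C`: 13.1 nM. Compound 3 `CO[C@@H]1C[C@@H]2O[C@@]2(C)C(=O)N(C)[C@@H](C(C)C)C(=O)N[C@H](Cc2cc(Cl)c(O)c(Cl)c2)C(=O)N[C@@H](C(C)(C)O)C(=O)O[C@H](c2ccccc2)[C@H](C)/C=C/C=C/1C`: 3.5 nM.

These three values come from a functional assay on A549 cells (Homo sapiens) for antiproliferative activity, read by MTT assay, with a stated time of 72 h; a higher number here means a weaker inhibitor, a lower number a stronger inhibitor. Compound 1 gives the highest number of the three; compound 2 lies within the scatter of it, while compound 3 lies beyond it. The difference between the cores of compound 1 and compound 3 is not broken down here. From compound 3 to compound 2 the change is methyl in place of hydrogen on a saturated chain carbon, two bonds along the chain from a saturated ring carbon, and it gave a 3.7-fold higher number from compound 3 to compound 2 (0.57 log units; beyond the scatter). Compound 4 `CC/C1=C\C=C\[C@@H](C)[C@@H](c2ccccc2)OC(=O)[C@H](C(C)C)NC(=O)[C@@H](Cc2cc(Cl)c(O)c(Cl)c2)NC(=O)[C@H](C(C)C)N(C)C(=O)/C(C)=C/C[C@H]1OC` is not yet measured; it differs from compound 1 by methyl in place of hydrogen on a saturated chain carbon bound to a double-bonded ring carbon. This is the same kind of change, but the place differs: in compound 2 the carbon is two bonds along the chain from a saturated ring carbon, in compound 4 it is bound to a double-bonded ring carbon. Resting on a 3.7-fold higher number from compound 3 to compound 2 (0.57 log units; beyond the scatter), compound 4 is expected to give 35 nM in this assay. That expected step, a 1.6-fold higher number from compound 1 to compound 4 (0.21 log units; within the scatter), is set smaller than the earlier one, as the two places are not the same. Compound 4 is expected to fall between 15 nM and 90 nM.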

Compound 4, half-maximal inhibitory concentration: 13.1 nM
Compound 4: the middle estimate sits 2.7-fold (0.43 log units) above what was measured; the whole stated range lies above it.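

In this assay the new step is a 1.6-fold lower number from compound 1 to compound 4 (0.22 log units; within the scatter). Set beside the earlier step, the same change does not carry over in size from one core to the other: the same change on two cores in this assay, a 3.7-fold higher number (0.57 log units; beyond the scatter) from compound 3 to compound 2 and a 1.6-fold lower number (0.22 log units; within the scatter) from compound 1 to compound 4, 6.2-fold (0.79 log units) apart, beyond the scatter of two such steps. Within the data shown here, with only one pair on each core, and with the change at a different place in each pair, these results do not separate the effect of the core from that of the place, and they say nothing about any further core.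

The compounds shown leave open how this series would read with a longer chain, such as propyl, at the place changed in compound 4. They also leave open what an amine or a hydroxyl on that chain would give.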